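The compounds below may be only part of what the source reports. "The series", "measured", "known", "first", "only" and "open" are said of these compounds alone.

Measured so far in a functional assay on KB cells (Homo sapiens) for cytotoxicity, read by MTT assay, with a stated time of 72 h; a lower number here means that less compound is needed, a higher number that more compound is needed for the effect:
compound 1 `O=C1/C(=C\c2ccc(F)cc2)c2ccccc2N1c1c(Cl)cccc1Cl` gives 5 ug/mL
compound 2 `Cc1ccc2nc(Cl)c(/C=C3\C(=O)N(c4c(Cl)cccc4Cl)c4ccccc43)cc2c1` gives 100 ug/mL
compound 3 `O=C1/C(=C\c2cccc(Oc3ccccc3)c2)c2ccccc2N1c1c(Cl)cccc1Cl` gives 5 ug/mL

In this assay compound 3 stands level with compound 1 at the digits shown, and these two together give the lowest numbers of the three, while compound 2 gives a number far higher, well beyond the scatter. Compound 4 `O=C1/C(=C\c2cccc(Br)c2)c2ccccc2N1c1c(Cl)cccc1Cl` has not yet been measured. It differs from compound 3 in one place: bromo in place of phenoxy on an aromatic carbon. Among the measured compounds shown here, no measured pair shows this change directly. Compound 1, which carries a small halogen on its ring, gives 5 ug/mL in this assay. On that basis the step of no change at the digits printed from compound 3 to compound 4 (within the scatter) is expected to stay within the scatter. For compound 4 the estimate is 5 ug/mL, ranging from 2 ug/mL to 15 ug/mL.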

Compound 4, concentration for half-maximal effect: 2 ug/mL
The estimate for compound 4 lay 2.5-fold (0.40 log units) above the measured number; measured number inside the range.
By their numbers in this assay, from the lowest: compound 4; then compounds 1 and 3 (each within the scatter of the next); then compound 2.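

In this assay, bromo in place of phenoxy on this aromatic carbon gives (a 2.5-fold lower number from compound 3 to compound 4 (0.40 log units; beyond the scatter)), so the phenoxy ring, with its seven heavy atoms, is not required here for a low number. The 3-bromophenyl in place of 4-fluorophenyl gives a step of the same modest size (a 2.5-fold lower number from compound 1 to compound 4 (0.40 log units; beyond the scatter)). No measurement of any property bears on these steps. Still open, on these data alone, is whether an amine or a carboxylic acid on this carbon would keep the number low. Also open, as far as these compounds go, is whether bromo would give the same result elsewhere on the ring.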